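Compound 4: swapping the ring on the ethenyl ester

This account rests on a few compounds, and the source may have more. Where it says the series, first, only, none or still open, it means among the compounds named here.

Measured so far in an ADME assay on HepG2 2.2.15 cells (Homo sapiens) for cytotoxicity; a lower number here means that less compound is tolerated, a higher number that more compound is tolerated
compound 1 `O=C(O)CCCC(=O)OCCc1c(-c2ccccc2Cl)c2cc(Cl)ccc2[nH]c1=O` gives 110000 nM
compound 2 `O=C(OCCc1c(-c2ccccc2Cl)c2cc(Cl)ccc2[nH]c1=O)C1CCCCC1` gives 38000 nM
compound 3 `O=C(/C=C/c1cccc(C(F)(F)F)c1)OCCc1c(-c2ccccc2Cl)c2cc(Cl)ccc2[nH]c1=O` gives > 1400000 nM (a limit, not a number)

Compound 3 stands at the limit of > 1400000 nM in this assay, at which 1 of the 3 values shown sits, and offers a limit rather than a number. The next compound to be tested is compound 4 `COc1ccc(/C=C/C(=O)OCCc2c(-c3ccccc3Cl)c3cc(Cl)ccc3[nH]c2=O)cc1OC` and it differs from compound 3 in a single group. The change 3,4-dimethoxyphenyl in place of 3-(trifluoromethyl)phenyl on a double-bonded chain carbon bound to a double-bonded chain carbon puts 3,4-dimethoxyphenyl in place of 3-(trifluoromethyl)phenyl on a double-bonded chain carbon bound to a double-bonded chain carbon.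

Among the compounds with values here, two measured steps bear on this. The step of an at least 12-fold higher number from compound 1 to compound 3 (1.10 log units; beyond the scatter) and the step of an at least 36-fold higher number from compound 2 to compound 3 (1.56 log units; beyond the scatter) are both large, and each brings in the 2-(3-(trifluoromethyl)phenyl)ethenyl group. On these data alone, both end at a limit, so their true size stays open, and neither alters the ring itself. Compound 4 keeps the ethenyl chain, so a high value is still expected, but no measurement shows how much of the large gain survives the ring swap. The estimated change is an at least 3.5-fold lower number from compound 3 to compound 4 (0.54 log units; beyond the scatter) and its size is uncertain. In this assay the expected value for compound 4 is 400000 nM with a range from 80000 nM to 1400000 nM as estimated here.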

Compound 4, half-maximal cytotoxic concentration: > 1200000 nM
Compound 4 was reported as a limit (the forecaster's own chance of this, stated with the estimate: 35%); middle value at least 3.0-fold (0.47 log units) from the limit.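

In this assay compound 4 is reported only as a limit, so its true value is not known: the limit of > 1200000 nM in this assay, at which 1 of the 4 values shown sits. Against the two esters without the ethenyl chain, the 2-(3,4-dimethoxyphenyl)ethenyl group still gives an at least 31-fold higher number from compound 2 to compound 4 (1.49 log units; beyond the scatter) and an at least 10-fold higher number from compound 1 to compound 4 (1.03 log units; beyond the scatter), which shows that the large rise seen with the 3-(trifluoromethyl)phenyl ring also appears with a ring carrying two methoxy groups and no fluorine. The step between compound 3 and compound 4 cannot be read, since both values are limits, so these data place neither ring ahead of the other at this position on the double-bonded chain carbon.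

On these data alone, how far the true values of compound 3 and compound 4 lie beyond their limits remains open, and so does any ranking of the two rings. Also open, as far as these compounds go, is whether the ethenyl link or the ring on it matters more, a question that an unsubstituted phenyl ring on the same chain, or a saturated ethyl link carrying the 3,4-dimethoxyphenyl ring, could begin to address.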